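Double-bond configuration at the chain end: compound 4

A few compounds are considered here, and "the series" means these few. Any claim that something is new, unique, unknown or untested is made for them only; others in the source may bear on it.

Measured in a functional assay on Hs-578T cells (Homo sapiens) for antiproliferative activity; a lower number here means a stronger inhibitor of growth, a higher number a weaker inhibitor of growth:
- compound 1 `COCCCCCCCCCCCCCCC/C=C1/CC(CO)(COC(=O)C(C)(C)C)OC1=O`: 6.77 ug/mL
- compound 2 `COCCCCCCCCCCC/C=C1\CC(CO)(COC(=O)C(C)(C)C)OC1=O`: 7.34 ug/mL
- compound 3 `CC(C)(C)C(=O)OCC1(CO)C/C(=C\CCCCCCCCCCCCCCC=O)C(=O)O1`: > 10 ug/mL, a limit and not a number

Compound 3 has no number on this read-out, only (the limit of > 10 ug/mL in this assay, at which 1 of the 3 values shown sits). Compound 1 and compound 2 lie within the scatter of each other.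

Compound 4 `CC(C)(C)C(=O)OCC1(CO)C/C(=C/CCCCCCCCCCCCCCC=O)C(=O)O1` is still unmeasured. Its difference from compound 3 is the two compounds have the same atoms and bonds; at least one stereo element is drawn with a configuration in one of them and without one in the other: 1 of 2 stereo elements differ; a double bond is drawn E in compound 3 and Z in compound 4. The double bond is drawn E in compound 3 and Z in compound 4.

For the measured compounds named here, the only measured step, an at least 1.3-fold higher number from compound 2 to compound 3 (0.13 log units; that floor lies within the scatter), changes the chain end and leaves the configuration of the double bond as it is. Going by the values given here, it is therefore no direct guide, and no measured step isolates this change. Going by these compounds, with nothing measured against it, no step beyond the scatter is expected in this assay, and the direction stays open.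

A report of only a limit is expected about as often as a number. For compound 4 the expected value is 10 ug/mL, with an estimated range of 6 ug/mL to 18 ug/mL. The expected size of the change is a number no higher from compound 3 to compound 4 (the limit leaves the size open).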

Compound 4, concentration for 50% growth inhibition: > 10 ug/mL
Compound 4: no number, only a limit (the forecaster's own chance of this, stated with the estimate: 50%); the middle value lies on the limit itself.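

In this assay compound 4 also gives only a limit, > 10 ug/mL, so the formyl-ended chain now yields no number with the double bond drawn either way. The step between the two formyl compounds cannot be read, because both stop at the same ceiling: the limit of > 10 ug/mL in this assay, at which 2 of the 4 values shown sit. Against the methoxy-ended chain, the comparison gives an at least 1.4-fold higher number from compound 1 to compound 4 (0.16 log units; that floor lies within the scatter), so a real loss of growth inhibition on replacing the methoxy end with formyl is suggested by the limit but not established.

Going by these compounds, whether the configuration of this double bond affects growth inhibition at all remains open, since neither formyl compound has a number to compare. Also open, on these data alone, is whether a carboxylic acid or an amine at the chain end, in place of formyl, would give a value under the limit and so make the end of the chain readable in this assay.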